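Aryl groups on the ring amine and adenosine receptor activity

The source may hold more compounds than are shown below. What is called first, only, known or untested is meant among the compounds shown, and "the series" means these compounds.

Measured compounds:
compound 1, `CC(C)N1CCN(Cc2csc(N)c2C(=O)c2ccc(Cl)cc2)CC1`: -7.4%
compound 2, `Nc1scc(CN2CCN(c3ccc(Cl)c(C(F)(F)F)c3)CC2)c1C(=O)c1ccc(Cl)cc1`: -60%
compound 3, `Nc1scc(CN2CCN(c3cccc(F)c3)CC2)c1C(=O)c1ccc(Cl)cc1`: -82%

In a functional assay on CHO cells with adenosine receptor A1 (Homo sapiens) as the target, read by cAMP accumulation and immunoassay, with a stated time of 6 min, tested at 10 uM (on this read-out higher numbers stand for a weaker effect at the one concentration tested and lower numbers for a stronger effect), compound 1 gives -7.4%, compound 2 gives -60% and compound 3 gives -82%. Compound 3 therefore stands lowest of the three in this assay, with compound 2 nearest and compound 1 furthest away.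

Compound 4, `Nc1scc(CN2CCN(c3ccc(F)c(Cl)c3)CC2)c1C(=O)c1ccc(Cl)cc1`, has not yet been measured. It differs from compound 3 in one place: 3-chloro-4-fluorophenyl in place of 3-fluorophenyl on an amine nitrogen in a ring.

Among the compounds with values here, two steps bear on this change. Going from an isopropyl to an aryl group on the ring amine gave a number 52.6 percentage points lower from compound 1 to compound 2 (beyond the scatter) and a number 74.6 percentage points lower from compound 1 to compound 3 (beyond the scatter), while exchanging one aryl group for another gave a number 22 percentage points lower from compound 2 to compound 3 (beyond the scatter). Compound 4 keeps an aryl group on that nitrogen, so a number close to that of compound 3 in this assay is expected, with the added chlorine possibly pulling it a little toward compound 2. The expected step is a number 7 percentage points higher from compound 3 to compound 4 (within the scatter), within the scatter. Compound 4 is thus estimated at -75% in this assay, ranging from -95% to -50%.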

Compound 4, a percentage reported as activity, at one concentration (the size of the read-out at that concentration, not a potency): -78%
Compound 4: the middle estimate sits 3 percentage points above what was measured; measured number inside the range.
By their numbers in this assay, from the lowest: compounds 3 and 4 (each within the scatter of the next); then compound 2; then compound 1.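

In this assay, 3-chloro-4-fluorophenyl in place of 3-fluorophenyl on the ring amine nitrogen gives a number 4 percentage points higher from compound 3 to compound 4 (within the scatter), so this position accepts the added chlorine with no readable change. The new group also matches the separation already seen for 3-fluorophenyl, giving a number 18 percentage points lower from compound 2 to compound 4 (beyond the scatter) and a number 70.6 percentage points lower from compound 1 to compound 4 (beyond the scatter), which places 4-chloro-3-(trifluoromethyl)phenyl apart from the other two aryl groups while isopropyl remains furthest from all three. No supporting measurement accounts for these differences.

The compounds shown leave open whether a methoxy group, an amine or a carboxylic acid on the phenyl ring would fit as well, and whether a benzyl group on the nitrogen would behave like the aryl groups. A single tested concentration also cannot show whether compound 3 and compound 4 share the same potency.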